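A few compounds are considered here, and "the series" means these few. Any claim that something is new, unique, unknown or untested is made for them only; others in the source may bear on it.

The measured compounds:

Compound 1, `CC(C(=O)NCc1ccc(C(F)(F)F)nc1-c1ccccc1)c1ccc(NS(C)(=O)=O)c(F)c1`, in an assay on CHO cells for antagonist activity at transient receptor potential cation channel subfamily V member 1 (Homo sapiens), read by FLIPR (a higher number here means a weaker inhibitor, a lower number a stronger inhibitor), gives 6.4 nM.
Compound 2, `CC(C(=O)NCc1ccc(C(F)(F)F)nc1-c1ccco1)c1ccc(NS(C)(=O)=O)c(F)c1`, in this assay gives 5.8 nM.

Compound 2 stands with compound 1 at numbers that cannot be told apart, the step of a 1.1-fold lower number from compound 1 to compound 2 (0.04 log units; within the scatter) lying within the scatter. Compound 3, `CC(C(=O)NCc1ccc(C(F)(F)F)nc1CCc1ccccc1)c1ccc(NS(C)(=O)=O)c(F)c1`, differs from compound 2 in one place: phenethyl in place of furan-2-yl on an aromatic carbon. For the measured compounds named here, only one measured step touches this position, the swap that gives a 1.1-fold lower number from compound 1 to compound 2 (0.04 log units; within the scatter), and it was flat; it exchanged one aromatic ring for another directly on the ring carbon, whereas the phenethyl of compound 3 carries its six-membered ring on a two-carbon chain, a change the existing pair does not cover. Compound 3 is therefore expected to sit near compound 2, with a step of about a 2.1-fold higher number from compound 2 to compound 3 (0.32 log units; beyond the scatter) in this assay, slightly toward a weaker number but with wide uncertainty. The estimate for compound 3 in this assay is 12 nM, expected to fall between 3 nM and 50 nM.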

Compound 3, inhibition constant: 1.4 nM
Beside the measured number, compound 3's estimate is 8.6-fold (0.93 log units) above it, and the stated range ends above it.
By their numbers in this assay, from the lowest: compound 3; then compounds 2 and 1 (each within the scatter of the next).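

Up to this point the position, on an aromatic carbon next to the ring nitrogen, had carried only rings bonded directly to it, and exchanging those made no readable difference. In this assay, phenethyl in place of furan-2-yl gives a 4.1-fold lower number from compound 2 to compound 3 (0.62 log units; beyond the scatter), and phenethyl in place of phenyl gives a 4.6-fold lower number from compound 1 to compound 3 (0.66 log units; beyond the scatter), so this position does respond to the group it carries, and phenethyl separates from both directly attached rings. Nothing at hand accounts for this gain.

Going by these compounds, whether the length of the chain or the aromatic ring at its end matters remains open; a benzyl, a phenylpropyl or a cyclohexylethyl group would bear on that. On these data alone, how an amine or an ether link at this position would compare also remains open.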